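The source may report more compounds than this note shows. Statements on the series, on what has been measured and on what is new or still open speak of the compounds shown alone.

Measured to date in an assay on HeLa cells for displacement of a labelled ligand from adenosine receptor A3 (Homo sapiens), read by scintillation counting, with a stated time of 180 min, tested at 10 uM; on this read-out higher numbers stand for more inhibition at the one concentration tested (going by the name of the read-out) and lower numbers for less inhibition:
- compound 1 `N=c1oc2ccc(Br)cc2cc1C(=O)NCC(O)CO` gives 10%
- compound 2 `N=c1oc2ccc(Br)cc2cc1C(=O)NCCO` gives 0%
- compound 3 `CCC(CO)NC(=O)c1cc2cc(Br)ccc2oc1=N` gives 24%

On these numbers compound 3 stands highest of the three, with both steps leading to it beyond the scatter: a number 14 percentage points higher from compound 1 to compound 3 (beyond the scatter) and a number 24 percentage points higher from compound 2 to compound 3 (beyond the scatter). The remaining step, a number 10 percentage points lower from compound 1 to compound 2 (within the scatter), shows that losing a hydroxymethyl group from the amide substituent made no difference beyond the scatter.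

Compound 4 `N=c1oc2ccc(Br)cc2cc1C(=O)NC1CCCC1` has not yet been measured in this assay . Relative to compound 3 the change is cyclopentyl in place of 1-(hydroxymethyl)propyl on an amide-type nitrogen. Among the compounds with values here, the two steps that bear on it both enlarged the carbon part of the amide substituent and raised the read-out by a modest amount, while the one step that removed a hydroxyl-bearing group stayed within the scatter. Compound 4 removes the hydroxyl and keeps a carbon group of similar size on the amide nitrogen, so the expected step is small and, if anything, upward: a number 6 percentage points higher from compound 3 to compound 4 (within the scatter). For compound 4 the estimate is 30%, with a range of 10% to 55%.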

Compound 4, a percentage reported as inhibition, at one concentration (the size of the read-out at that concentration, not a potency): 0%
Estimate against measurement, compound 4: 30 percentage points above; measured number below the stated range.
By their numbers in this assay, from the lowest: compounds 2, 4 and 1 (each within the scatter of the next); then compound 3.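

Cyclopentyl in place of 1-(hydroxymethyl)propyl on the amide-type nitrogen keeps the count of 5 heavy atoms yet gives a number 24 percentage points lower from compound 3 to compound 4 (beyond the scatter), so that count alone does not set the read-out at this position. The other two new steps, no change at the digits printed from compound 2 to compound 4 (within the scatter) and a number 10 percentage points lower from compound 1 to compound 4 (within the scatter), put cyclopentyl within the scatter of the 2-hydroxyethyl and 2,3-dihydroxypropyl groups, which leaves compound 3 as the only one of the four clearly separated from the rest. No measurement at hand explains the drop seen with this change.

Compound 4 both removes the hydroxyl and adds a ring, so the compounds shown cannot separate these two differences. An open 1-ethylpropyl chain, or a cyclopentyl ring carrying a hydroxymethyl group, would divide them.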